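The source may report more compounds than this note shows. Statements on the series, on what has been measured and on what is new or still open speak of the compounds shown alone.

Measured in a functional assay on L5178Y cells (Mus musculus) for inhibition, read by MTT assay, with a stated time of 24 h; on this read-out lower numbers stand for stronger inhibition and higher numbers for weaker inhibition:
- Compound 1 `COc1cc(O)c2c(c1)O[C@H](c1ccc(O)cc1)C/C2=N\NC(=O)Cc1c[nH]c2ccccc12`: >= 11300 nM
- Compound 2 `COc1cc(O)c2c(c1)O[C@H](c1ccc(OCC3CO3)cc1)CC2=O`: >= 11300 nM

Compound 2 reaches no number in this assay: its >= 11300 nM is a limit. Compound 1 also gives only a limit, so the two share (the limit of >= 11300 nM in this assay, at which 2 of the 2 values shown sit).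

Compound 3 `CCN(CC)CC(O)COc1ccc([C@@H]2CC(=O)c3c(O)cc(OC)cc3O2)cc1` carries 2-(diethylamino)-1-hydroxyethyl in place of oxiran-2-yl on a saturated chain carbon bound to an oxygen on an aromatic ring. Going by the values given here, with no measured step to draw on, only a modest shift toward stronger inhibition is expected, and the result may well stay at the limit. The expected change is an at least 1.2-fold lower number from compound 2 to compound 3 (0.09 log units; that floor lies within the scatter). For compound 3 the estimated value is 9000 nM, with an expected range of 3000 nM to 30000 nM.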

Compound 3, half-maximal inhibitory concentration: >= 11300 nM
Compound 3: only a limit was reported; the forecaster's own chance of this, stated with the estimate: 55%; middle value at least 1.2-fold (0.09 log units) from the limit.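

No step can be read from compound 2 to compound 3 in this assay, since both stop at a limit: the limit of >= 11300 nM in this assay, at which 3 of the 3 values shown sit. The compounds shown leave open how strong the inhibition by any of them actually is.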